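The compounds below may be only part of what the source reports. "The series", "measured", "known", "first", "only" and "open" are said of these compounds alone.

The study concerns a small set of amides built on one shared core. Compound 1 is `CCCn1c(NC(=O)c2ccccn2)nc2cc(C(N)=O)cc(OC)c21`. In an assay for activation of interferon regulatory factor 3 (Homo sapiens), read by a luciferase reporter, with a stated time of 20 h (a lower number here means that less compound is needed, a higher number that more compound is needed for the effect), compound 1 gives > 100000 nM, which is a limit of the assay rather than a number. Compound 2, `CCCn1c(NC(=O)c2cccnn2)nc2cc(C(N)=O)cc(OC)c21`, differs from compound 1 by pyridazin-3-yl in place of pyridin-2-yl on a carbonyl carbon. In this assay compound 2 gives > 100000 nM, again a limit. Compound 3, `COc1cc(C(N)=O)cc2nc(NC(=O)c3ccccn3)n(CCCNC(=O)OCc3ccccc3)c12`, carries a changed core: set against compound 1 the difference is (benzyloxycarbonyl)amino in place of hydrogen on a saturated chain carbon, three bonds along the chain from an aromatic nitrogen. In this assay compound 3 gives > 100000 nM, also a limit. The step that the two limits leave unreadable from compound 1 to compound 2 therefore cannot be read, and the same holds for a step that the two limits leave unreadable from compound 1 to compound 3; all three values sit at the limit of > 100000 nM in this assay, at which 3 of the 3 values shown sit.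

Compound 4 is `COc1cc(C(N)=O)cc2nc(NC(=O)c3cccnn3)n(CCCNC(=O)OCc3ccccc3)c12` and has not been measured. It stands to compound 3 as compound 2 stands to compound 1: the change is pyridazin-3-yl in place of pyridin-2-yl on a carbonyl carbon, the same change in the same place, on a carbonyl carbon whose other neighbours are an amide-type nitrogen, made on the core of compound 3 instead of the core of compound 1. Because compound 1 and compound 2 both sit at the limit of > 100000 nM in this assay, at which 3 of the 3 values shown sit, the step from compound 3 to compound 4 is expected to be a step that the limit leaves unreadable from compound 3 to compound 4, with nothing in the measured pair to suggest a readable gain. Compound 4 is expected to give about 200000 nM, most probably reported once more as a limit, within a range from 50000 nM to 1000000 nM.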

Compound 4, half-maximal effective concentration: > 100000 nM
Compound 4: a limit, no number (the forecaster's own chance of this, stated with the estimate: 85%); the middle value does not contradict the limit.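

In this assay compound 4 gives > 100000 nM, which is a limit of the assay and not a number. No step can be read from compound 3 to compound 4 or from compound 2 to compound 4, and all the compounds shown stand at the same limit: the limit of > 100000 nM in this assay, at which 4 of the 4 values shown sit. The compounds shown leave open how pyridazin-3-yl and pyridin-2-yl, or the core of compound 1 and the core of compound 3, compare in this assay.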